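Hydroxyphenyl Sulfonamide Variant of a Benzoxazole Reference

The source may report more compounds than this note shows. Statements on the series, on what has been measured and on what is new or still open speak of the compounds shown alone.

Compound 1 `COc1ccc(S(=O)(=O)Nc2ccc(-c3nc4ccccc4o3)cc2)cc1` was examined in an assay on cells for inhibition of HSP60/HSP10 (Homo sapiens), with a stated time of 60 min; a higher number here means a weaker inhibitor, a lower number a stronger inhibitor. In this assay compound 1 reaches only a limit, > 100000 nM, so no number is reported for it. The other measured compound, compound 2 `O=S(=O)(Nc1ccc2oc(-c3ccc(NS(=O)(=O)c4cccc5nonc45)cc3)nc2c1)c1ccc(Cl)s1`, carries two sulfonamide arms and in this assay gives 13000 nM. Compound 1 thus sits at the weak end of the two values shown, as the line the limit of > 100000 nM in this assay, at which 1 of the 2 values shown sits, records. Compound 3 `O=S(=O)(Nc1ccc(-c2nc3ccccc3o2)cc1)c1ccccc1O` has not been measured; it differs from compound 1 in one place (2-hydroxyphenyl in place of 4-methoxyphenyl on a sulfonyl sulfur). Going by the values given here, no measured step links compound 1 and compound 3, and the change is small, so the step is expected to be no more than modest, an at least 1.2-fold lower number from compound 1 to compound 3 (0.09 log units; that floor lies within the scatter), in the direction of slightly stronger binding if anything. Compound 3 is therefore estimated at 80000 nM, with a range from 20000 nM to 300000 nM, and a limit is again quite possible.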

Compound 3, half-maximal inhibitory concentration: > 100000 nM
Compound 3: only a limit was reported; the forecaster's own chance of this, stated with the estimate: 55%; middle value at least 1.2-fold (0.09 log units) from the limit.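

Going by these compounds alone, compound 1 and compound 3 both end at a limit in this assay, so no step between them can be read. The compounds shown leave open whether 2-hydroxyphenyl and 4-methoxyphenyl on a sulfonyl sulfur differ at all in this assay.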